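The source may hold more compounds than are shown below. What is called first, only, known or untested is meant among the compounds shown, and "the series" means these compounds.

Measured compounds:
- compound 1 `Cc1ccc(-c2nc3ccccc3s2)cc1NC(=O)c1cc([N+](=O)[O-])c(N2CCCCC2)cc1Cl`: < 1 10^-6 cm/s
- compound 2 `O=C(Nc1cccc(-c2nc3ccccc3s2)c1)c1cc([N+](=O)[O-])c(O)cc1Cl`: 307 10^-6 cm/s
- compound 3 `COc1ccc(-c2nc3ccccc3s2)cc1NC(=O)c1cc([N+](=O)[O-])c(N2CCN(C)CC2)cc1Cl`: 676 10^-6 cm/s

All three were tested in an ADME assay for permeability, using PAMPA, at pH 7.4; a higher number here means that the compound crosses the layer faster, a lower number that the compound crosses the layer more slowly. Compound 1 gives < 1 10^-6 cm/s in this assay, which is a limit of the assay rather than a number (the limit of < 1 10^-6 cm/s in this assay, at which 1 of the 3 values shown sits). Compound 2 gives 307 10^-6 cm/s, and compound 3 gives 676 10^-6 cm/s.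

The next compound, compound 4 `Cc1ccc(-c2nc3ccccc3s2)cc1NC(=O)c1cc([N+](=O)[O-])ccc1Cl`, has not yet been measured in this assay. It differs from compound 1 in one place: hydrogen in place of piperidin-1-yl on an aromatic carbon. In the words of that change, hydrogen takes the place of piperidin-1-yl on an aromatic carbon of the shared core. For the measured compounds named here, no measured pair in this set shows the same change, so the size of the step is uncertain. Given that compound 2 gives 307 10^-6 cm/s without any such ring, a step upward is expected, as an at least 150-fold higher number from compound 1 to compound 4 (2.17 log units; beyond the scatter). Compound 4 is estimated at 150 10^-6 cm/s, within a range from 5 10^-6 cm/s to 600 10^-6 cm/s.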

Compound 4, apparent permeability: 41 10^-6 cm/s
Estimate against measurement, compound 4: 3.7-fold (0.56 log units) above, and the stated range covers the measured number.
By their numbers in this assay, from the lowest: compound 4; then compound 2; then compound 3. At a limit, below all of these: compound 1.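

In this assay, for the compounds shown here, hydrogen in place of piperidin-1-yl on this aromatic carbon, ortho to a nitro group, gives an at least 41-fold higher number from compound 1 to compound 4 (1.61 log units; beyond the scatter) and is the first measured change confined to this position. It shows that the group at this one place can by itself move the number beyond the usual scatter while the rest of the core of compound 1 stays the same. Compound 1 stands at a limit of the assay and not at a number: the limit of < 1 10^-6 cm/s in this assay, at which 1 of the 4 values shown sits.

This single pair cannot show whether other groups at this position would behave like piperidin-1-yl or like hydrogen, and compound 2 and compound 3 each differ from compound 1 in more than one place. From the compounds shown here alone, how morpholin-4-yl, an open-chain amine such as dimethylamino or a carboxylic acid would read on this carbon remains open.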